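Replacing an aryl group by benzoyl on a sulfonamide nitrogen

The source may report more compounds than this note shows. Statements on the series, on what has been measured and on what is new or still open speak of the compounds shown alone.

The measured compounds and their values in an ADME assay on the whole organism for pharmacokinetics, with Homo sapiens as the target; on this read-out higher numbers stand for higher oral bioavailability and lower numbers for lower oral bioavailability:
- compound 1, `O=[N+]([O-])c1cccc(NS(=O)(=O)c2ccc3nc(-c4ccccc4)c(-c4ccccc4)nc3c2)c1`: 85.6%
- compound 2, `O=S(=O)(Nc1ccccn1)c1ccc2nc(-c3ccccc3)c(-c3ccccc3)nc2c1`: 100%
- compound 3, `CC(=O)c1cccc(NS(=O)(=O)c2ccc3nc(-c4ccccc4)c(-c4ccccc4)nc3c2)c1`: 96.9%

All three share one core and differ only in the group carried on the sulfonamide nitrogen. Compound 3 lies within the scatter of compound 2 and stands above compound 1 by a margin beyond the scatter, as the step of a number 11.3 percentage points higher from compound 1 to compound 3 (beyond the scatter) shows. The other steps are a number 14.4 percentage points higher from compound 1 to compound 2 (beyond the scatter) and a number 3.1 percentage points lower from compound 2 to compound 3 (within the scatter).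

The unmeasured compound 4, `O=C(NS(=O)(=O)c1ccc2nc(-c3ccccc3)c(-c3ccccc3)nc2c1)c1ccccc1`, continues this series with one change: benzoyl in place of 3-acetylphenyl on a sulfonamide nitrogen. Every measured step in this set also concerns the group on that nitrogen, and none of them moved the number by more than a modest amount; the swap from 3-nitrophenyl to pyridin-2-yl and the swap from 3-acetylphenyl to pyridin-2-yl both left the values high. Nothing measured here describes an acyl group in that place, so the step to compound 4 carries more uncertainty than the gaps among the three measured compounds.

On that basis the step from compound 3 to compound 4 is expected to be small, a number 6.9 percentage points lower from compound 3 to compound 4 (within the scatter), and most likely within the scatter. Compound 4 is therefore estimated at 90% in this assay, with a range from 70% to 100%.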

Compound 4, oral bioavailability: 100%
Compound 4: the middle estimate sits 10 percentage points below what was measured, and the stated range covers the measured number.
By their numbers in this assay, from the lowest: compound 1; then compounds 3, 2 and 4 (each within the scatter of the next).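

In this assay, for the compounds shown here, the earlier compounds carried only an aromatic ring on the sulfonamide nitrogen, and compound 4 shows that an acyl group in that place, here benzoyl, can also give a high number: the steps read a number 3.1 percentage points higher from compound 3 to compound 4 (within the scatter) and no change at the digits printed from compound 2 to compound 4 (within the scatter) and so do not separate compound 4 from compound 3 or compound 2. Going by these compounds alone, the comparison with the 3-nitrophenyl group gives a number 14.4 percentage points higher from compound 1 to compound 4 (beyond the scatter) and leaves compound 1 as the only compound of the four set apart from the rest, so the benzoyl group joins pyridin-2-yl and 3-acetylphenyl on the high side of that gap. Nothing at hand explains why swapping the aromatic ring for benzoyl on this nitrogen leaves the number so high.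

As far as these compounds go, it stays open whether the high numbers depend on the ring within the benzoyl group, which a simple chain such as hexanoyl in the same place could test. From the compounds shown here alone, it also stays open how a benzoyl ring carrying an amine or a carboxylic acid would behave in this assay on this shared core.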